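This account rests on a few compounds, and the source may have more. Where it says the series, first, only, none or still open, it means among the compounds named here.

Measured in a functional assay with Rattus norvegicus as the target; a lower number here means that less compound is needed, a higher number that more compound is needed for the effect:
- compound 1 `CC1(C)C=C(n2ccccc2=O)c2cc(S(=O)(=O)N=[N+]=[N-])ccc2O1`: 16.2 nM
- compound 2 `CC1(C)C=C(n2ccccc2=O)c2cc(S(=O)(=O)NCCO)ccc2O1`: 110 nM
- compound 3 `CC1(C)C=C(n2ccccc2=O)c2cc(S(=O)(=O)Nc3ccc([N+](=O)[O-])cc3)ccc2O1`: 2090 nM

Compound 3 has the highest number of the three, and its steps to both others lie beyond the scatter. The next structure is compound 4 `CC1(C)C=C(n2ccccc2=O)c2cc(S(=O)(=O)Oc3ccccc3)ccc2O1`, with phenoxy in place of (4-nitrophenyl)amino on a sulfonyl sulfur.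

All measured steps are changes on the same sulfonyl sulfur. The smallest is a 6.8-fold higher number from compound 1 to compound 2 (0.83 log units; beyond the scatter). Larger ones are a 19-fold higher number from compound 2 to compound 3 (1.28 log units; beyond the scatter) and a 130-fold higher number from compound 1 to compound 3 (2.11 log units; beyond the scatter). These show that this group can shift this assay strongly, and the two large steps both end at the (4-nitrophenyl)amino group. Within the data shown here, no measured compound carries phenoxy, and no measured step replaces a sulfonamide nitrogen with oxygen, so the size of the new step is poorly constrained. Compound 4 keeps an aromatic ring of carbon only, as compound 3 does, so a full return to the value of compound 1 at 16.2 nM is not the central expectation.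

A modest move towards a lower number is expected, estimated as a 3.0-fold lower number from compound 3 to compound 4 (0.48 log units; beyond the scatter). The estimated value for compound 4 is 700 nM, with an expected range of 100 nM to 4000 nM.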

Compound 4, half-maximal effective concentration: 2.51 nM
Compound 4: the middle estimate sits 280-fold (2.45 log units) above what was measured, outside the stated range (below it).
By their numbers in this assay, from the lowest: compound 4; then compound 1; then compound 2; then compound 3.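

In this assay, compound 4 has the lowest number of the series, and its steps to all three others are beyond the scatter. The step of an 830-fold lower number from compound 3 to compound 4 (2.92 log units; beyond the scatter) is the largest seen on this sulfonyl sulfur, and since compound 3 and compound 4 each carry one six-membered aromatic ring of carbon only, such a ring here does not by itself go with a high number. Phenoxy also passes the other two groups, with a 44-fold lower number from compound 2 to compound 4 (1.64 log units; beyond the scatter) and a 6.5-fold lower number from compound 1 to compound 4 (0.81 log units; beyond the scatter), so azido no longer marks the low end at this position, and nothing measured in the series accounts for these steps.

The change from compound 3 to compound 4 swaps the atom on the sulfur and removes the nitro group in one move, so the share of each stays unresolved; phenylamino or 4-nitrophenoxy on the sulfonyl sulfur would separate the two. Also open, as far as these compounds go, is whether the low number depends on the aromatic ring of phenoxy, which a short alkoxy group such as methoxy or ethoxy in its place would test.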